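This account rests on a few compounds, and the source may have more. Where it says the series, first, only, none or still open, it means among the compounds named here.

Measured in a functional assay on A2058 cells (Homo sapiens) for antiproliferative activity, read by luminescence and CellTiter-Glo, with a stated time of 96 h; on this read-out lower numbers stand for stronger inhibition and higher numbers for weaker inhibition:
Compound 1 `O=C(Nc1ccc(F)cc1)c1n[nH]cc1NC(=O)c1c(F)ccc(-c2cccc(O)c2)c1F`: "not determined" (no result reported)
Compound 2 `NC(=O)c1cccc(-c2ccc(F)c(C(=O)Nc3c[nH]nc3C(=O)Nc3ccc(F)cc3)c2F)c1`: 1990 nM

Going by the values given here, compound 2, at 1990 nM, holds the only number in the set, so it cannot be ranked against another compound. Compound 3 `Nc1ccc(-c2ccc(F)c(C(=O)Nc3c[nH]nc3C(=O)Nc3ccc(F)cc3)c2F)cn1` differs from compound 2 in one place: 6-aminopyridin-3-yl in place of 3-carbamoylphenyl on an aromatic carbon. Here, 6-aminopyridin-3-yl stands in place of 3-carbamoylphenyl on an aromatic carbon. Among the compounds with values here, no measured step exists to guide the size of this change. The expected step in this assay is a 2.8-fold lower number from compound 2 to compound 3 (0.45 log units; beyond the scatter), a modest move toward stronger inhibition, and this expectation is uncertain. For compound 3 the estimated value is 700 nM, with an expected range from 130 nM to 3500 nM.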

Compound 3, half-maximal inhibitory concentration: 8540 nM
The estimate for compound 3 lay 12-fold (1.09 log units) below the measured number; the whole stated range lies below it.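

In this assay, the aromatic carbon ortho to a fluoro group proves responsive to the choice of ring attached there: 6-aminopyridin-3-yl in place of 3-carbamoylphenyl gives a 4.3-fold higher number from compound 2 to compound 3 (0.63 log units; beyond the scatter), so of these two groups, 3-carbamoylphenyl gives the stronger inhibition. Nothing available explains this step. From the compounds shown here alone, it remains open whether the ring nitrogen or the amine of compound 3 goes with the weaker inhibition, a question that 3-aminophenyl or unsubstituted pyridin-3-yl at this carbon could separate. Going by these compounds, how a 3-carboxyphenyl group would compare with 3-carbamoylphenyl also remains open.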